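Fluoro for methoxy on the chain of compound 2

The compounds below may be only part of what the source reports. "The series", "measured", "known", "first", "only" and "open" are said of these compounds alone.

Measured so far:
- compound 1 `COc1ccc(C(c2ccc(OC)c(OC)c2)[C@@H](C)[C@H](C)CO)cc1OC`: > 100000 nM
- compound 2 `COC[C@@H](C(C)C)C(c1ccc(O)c(OC)c1)c1ccc(O)c(OC)c1`: 54000 nM
- compound 3 `CCCCCCCC[C@H](C(C)C)C(c1ccc(O)c(OC)c1)c1ccc(O)c(OC)c1`: 3700 nM

In a functional assay on HL-60 cells (Homo sapiens) for cytotoxicity, read by WST assay, with a stated time of 48 h (on this read-out lower numbers stand for stronger inhibition and higher numbers for weaker inhibition), compound 1 gives only a limit, > 100000 nM, and no number. For the measured compounds named here, of the two numbers known, compound 2 stands at the higher one with 54000 nM in this assay, while compound 3 sits lower at 3700 nM, a gap beyond the usual scatter. No pair of these compounds differs in one place, so no single step can be read from them; the gap between compound 2 and compound 3 involves both the chain group and its length.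

Compound 4 `COc1cc(C(c2ccc(O)c(OC)c2)[C@@H](CF)C(C)C)ccc1O` is the next one to be measured in this assay. It differs from compound 2 as follows: fluoro in place of methoxy on a saturated chain carbon, three bonds along the chain from two aromatic carbons.

The step from compound 2 to compound 4 is expected to be small, likely within the scatter, perhaps leaning towards a lower number. The estimate for compound 4 in this assay is 40000 nM, between 15000 nM and 100000 nM, which means an expected step of a 1.4-fold lower number from compound 2 to compound 4 (0.13 log units; within the scatter).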

Compound 4, half-maximal inhibitory concentration: 39000 nM
Beside the measured number, compound 4's estimate is 1.0-fold (0.01 log units) above it, within the range that was stated.
By their numbers in this assay, from the lowest: compound 3; then compounds 4 and 2 (each within the scatter of the next). At a limit, above all of these: compound 1.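

In this assay, for the compounds shown here, the one step that can be read in one place is a 1.4-fold lower number from compound 2 to compound 4 (0.14 log units; within the scatter), so methoxy and fluoro cannot be told apart on this saturated chain carbon, three bonds along the chain from two aromatic carbons. The change takes away the one hydrogen-bond acceptor counted for methoxy and one heavy atom, and the read-out does not move beyond the scatter, so the methoxy oxygen is not needed to hold this level. The step lies at the weak end of the read-out, close to the limit of the assay: the limit of > 100000 nM in this assay, at which 1 of the 4 values shown sits.

Open, as far as these compounds go, is whether an amine or a carboxylic acid at this place on the chain would shift the number beyond the scatter. Going by these compounds alone, also open is how much of the lower number of compound 3, at 3700 nM, belongs to its chain, with no one-place step leading to it.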